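From butyl to 4-fluorophenyl on a sulfonyl sulfur

The source may report more compounds than this note shows. Statements on the series, on what has been measured and on what is new or still open speak of the compounds shown alone.

In a functional assay on Huh-7 cells (Homo sapiens) for cytotoxicity, read by MTT assay, with a stated time of 72 h (a lower number here means that less compound is tolerated, a higher number that more compound is tolerated), compound 1 (`CCCCS(=O)(=O)N1CCC2(CC1)OOC1(CCCCCC1)OO2`) gives > 100 ug/mL as its reading, which is a limit of the assay and not a number. Compound 2 (`O=S(=O)(c1ccc(F)cc1)N1CCC2(CC1)OOC1(CCCC1)OO2`) gives > 100 ug/mL as its reading, again a limit. Compound 3 (`O=S(=O)(c1ccc(F)cc1)N1CCC2(CC1)OOC1(CCCCC1)OO2`) gives > 100 ug/mL as its reading, also a limit. Compound 1 therefore stands with the other two compounds (the limit of > 100 ug/mL in this assay, at which 3 of the 3 values shown sit), and no order among the three can be read from these results.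

Compound 4 (`O=S(=O)(c1ccc(F)cc1)N1CCC2(CC1)OOC1(CCCCCC1)OO2`) keeps the core of compound 1 but has 4-fluorophenyl in place of butyl on a sulfonyl sulfur. Going by the values given here, no measured pair isolates this change, so the expectation rests only on the shared limit. In this assay the expected step (a step that the limit leaves unreadable from compound 1 to compound 4) is estimated to lie within the scatter, with no direction favoured. Compound 4 is estimated at 110 ug/mL (expected range 50 ug/mL to 250 ug/mL), and its reading may well be reported as a limit again.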

Compound 4, half-maximal cytotoxic concentration: > 100 ug/mL
Compound 4: a limit, no number (the forecaster's own chance of this, stated with the estimate: 80%); the middle value lies beyond the limit too.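

In this assay compound 4 gives > 100 ug/mL as its reading, a limit and not a number. Going by these compounds alone, no step from compound 1 to compound 4 can therefore be read: the limit of > 100 ug/mL in this assay, at which 4 of the 4 values shown sit. The compounds shown leave open whether butyl and 4-fluorophenyl differ here, and where any half-maximal cytotoxic concentration lies.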